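The source may hold more compounds than are shown below. What is called first, only, known or untested is meant among the compounds shown, and "the series" means these compounds.

Measured so far:
compound 1, `COc1ccc(-n2cc(COc3cccc(NC(=O)Nc4ccc(Cl)c(C(F)(F)F)c4)c3)nn2)cc1`: 4680 nM
compound 2, `O=C(Nc1cccc(OCc2cn(-c3ccc(Br)cc3)nn2)c1)Nc1ccc(Cl)c(C(F)(F)F)c1`: 2730 nM

Among the compounds with values here, in a functional assay on HepG2 cells (Homo sapiens) for inhibition, read by MTT assay, with a stated time of 72 h (a lower number here means a stronger inhibitor, a higher number a weaker inhibitor), compound 2 has the lowest number of the two, yet the only measured step, a 1.7-fold lower number from compound 1 to compound 2 (0.23 log units; within the scatter), lies within the scatter, so the two compounds cannot be ranked. Compound 3, `O=C(Nc1cccc(OCc2cn(-c3cccc(I)c3)nn2)c1)Nc1ccc(Cl)c(C(F)(F)F)c1`, is built from compound 2 by one change: 3-iodophenyl in place of 4-bromophenyl on an aromatic nitrogen. Within the data shown here, no measured step swaps bromine for iodine or moves the substituent around this phenyl, so the expectation rests on compound 2 alone and on the fact that the one known change on this ring produced nothing beyond the scatter. The step of a 1.1-fold lower number from compound 2 to compound 3 (0.02 log units; within the scatter) is therefore expected to stay within the scatter. For compound 3 in this assay the estimate is 2600 nM, with a range of 900 nM to 7500 nM.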

Compound 3, half-maximal inhibitory concentration: 4780 nM
Compound 3: middle estimate off by 1.8-fold (0.26 log units), on the low side; the range from low to high includes it.
By their numbers in this assay, from the lowest: compounds 2, 1 and 3 (each within the scatter of the next).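

In this assay the change to 3-iodophenyl gives a 1.8-fold higher number from compound 2 to compound 3 (0.24 log units; within the scatter) and a 1.0-fold higher number from compound 1 to compound 3 (0.01 log units; within the scatter) and both steps lie within the scatter. This position on the aromatic nitrogen has now carried 4-methoxyphenyl, 4-bromophenyl and 3-iodophenyl with no readable difference, even with the substituent at a different place on the phenyl. Nothing measured bears on the reason for this result.
The halogen and its place changed together. The compounds leave their separate contributions open, which 4-iodophenyl or 3-bromophenyl could address. Also open, on these data alone, is whether a phenyl bearing an amine or a carboxylic acid would go beyond the scatter.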